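The source may hold more compounds than are shown below. What is called first, only, known or untested is meant among the compounds shown, and "the series" means these compounds.

Working notes on the salicylanilide set in an assay on isolated protein for inhibition of thiosulfate sulfurtransferase (Homo sapiens), with a stated time of 60 min, in the absence of a further agent; on this read-out lower numbers stand for stronger inhibition and higher numbers for weaker inhibition.

Compound 1 `O=C(Nc1cccc(Cl)c1)c1cc(Br)cc(Br)c1O` carries two bromo groups on the acid-side ring and a chloro group on the aniline ring. In this assay compound 1 gives > 100000 nM, which is a limit of the assay and not a number. Compound 2 `O=C(Nc1ccccc1)c1cc(Br)ccc1O` keeps one bromo group and an unsubstituted aniline ring. In this assay compound 2 gives > 100000 nM, again a limit rather than a measured number. Compound 3 `O=C(Nc1cccc(Cl)c1)c1ccccc1O` has no bromo group at all but keeps the chloro group on the aniline ring. In this assay compound 3 gives > 100000 nM, also a limit.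

Among the measured compounds shown here, compound 2 therefore stands nowhere apart from the others: every value so far is a limit, as summarised by the limit of > 100000 nM in this assay, at which 3 of the 3 values shown sit, so no ordering within the set can be read.

The next step goes from compound 2 to compound 4 `O=C(Nc1ccccc1)c1cccc(Br)c1`. The change is hydrogen in place of hydroxy on an aromatic carbon, ortho to the amide and para to the bromo group. For the measured compounds named here, no measured pair separates by a single change, so no step size is known. Since compound 2 sits at the limit, with > 100000 nM, no movement beyond the scatter is expected. Compound 4 is estimated at 150000 nM (range 50000 nM to 500000 nM), most likely reported only as a limit, an expected step that the limit leaves unreadable from compound 2 to compound 4.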

Compound 4, half-maximal inhibitory concentration: > 100000 nM
Compound 4 gave a limit, no number; the forecaster's own chance of this, stated with the estimate: 85%; the middle value does not contradict the limit.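

No step can be read from compound 2 to compound 4, as both values are limits and not numbers in this assay, and the whole set stands the same way: the limit of > 100000 nM in this assay, at which 4 of the 4 values shown sit.

The compounds shown leave open whether any change to the shared core gives a measurable number in this assay, and so what replacing hydroxy with hydrogen does on this read-out.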